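The source may hold more compounds than are shown below. What is called first, only, known or untested is meant among the compounds shown, and "the series" means these compounds.

Compound 3 `CC1CCN(C2CCN(S(=O)(=O)c3ccccc3Br)CC2)CC1` gives the lowest number among the three measured compounds in a functional assay on DLD-1 cells (Homo sapiens) for antiproliferative activity, read by CellTiter-Glo, with a stated time of 72 h (on this read-out higher numbers stand for weaker inhibition and lower numbers for stronger inhibition), where compound 3 gives 3 nM. Its nearest neighbour is compound 1 `CC1CCN(C2CCN(S(=O)(=O)c3cccc(Br)c3)CC2)CC1`, which in this assay gives 3.2 nM. The step of a 1.1-fold lower number from compound 1 to compound 3 (0.03 log units; within the scatter) is within the scatter, so no order between the two can be read. The furthest is compound 2 `Cc1cccc(S(=O)(=O)N2CCC(N3CCC(C)CC3)CC2)c1`, with 25 nM in this assay. The step of an 8.3-fold lower number from compound 2 to compound 3 (0.92 log units; beyond the scatter) lies beyond the scatter.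

Compound 4 `CC1CCN(C2CCN(S(=O)(=O)c3cccnc3)CC2)CC1` is not yet measured. It differs from compound 3 in one place: pyridin-3-yl in place of 2-bromophenyl on a sulfonyl sulfur. Among the measured compounds shown here, two measured steps bear on this. The step of a 1.1-fold lower number from compound 1 to compound 3 (0.03 log units; within the scatter) shows that exchanging 3-bromophenyl for 2-bromophenyl changed little. The step of a 7.8-fold higher number from compound 1 to compound 2 (0.89 log units; beyond the scatter), a methyl in place of the bromo, raised the number, and the step of an 8.3-fold lower number from compound 2 to compound 3 (0.92 log units; beyond the scatter) points the same way: the bromo-bearing rings give the lower numbers. For the measured compounds named here, compound 4 carries no bromine, and its pyridin-3-yl brings a hydrogen-bond acceptor for which no measured compound offers a comparison. The chemist therefore expects a step of about a 13-fold higher number from compound 3 to compound 4 (1.12 log units; beyond the scatter), towards a higher number in this assay. The estimate for compound 4 in this assay is 40 nM, with a range from 8 nM to 200 nM.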

Compound 4, half-maximal inhibitory concentration: 2400 nM
Estimate against measurement, compound 4: 60-fold (1.78 log units) below, outside the stated range (above it).
By their numbers in this assay, from the lowest: compounds 3 and 1 (each within the scatter of the next); then compound 2; then compound 4.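

In this assay, among the compounds shown here, the group on the sulfonyl sulfur turns out to matter far more than the earlier compounds showed: pyridin-3-yl in place of 2-bromophenyl gives an 800-fold higher number from compound 3 to compound 4 (2.90 log units; beyond the scatter) and in place of 3-bromophenyl gives a 750-fold higher number from compound 1 to compound 4 (2.88 log units; beyond the scatter) in the same direction. Bromine alone does not cover this change, as 3-methylphenyl also carries no bromine, yet pyridin-3-yl in its place gives a 96-fold higher number from compound 2 to compound 4 (1.98 log units; beyond the scatter) and that step exceeds a 7.8-fold higher number from compound 1 to compound 2 (0.89 log units; beyond the scatter) among the carbon-only rings. Nothing measured here gives a reason for this drop, so the result stands as an observation only.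

Compound 4 differs from the others both in its ring nitrogen and in having no substituent on the ring, and these compounds cannot separate the two. A plain phenyl would speak to the first and a bromopyridin-3-yl to the second, while a chloro or methoxy group on the phenyl ring would show whether bromo is special among substituents at this position.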